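Acetyl in Place of Methyl on a Potent Ether

A few compounds are considered here, and "the series" means these few. Any claim that something is new, unique, unknown or untested is made for them only; others in the source may bear on it.

Measured in an assay on membranes from brain for displacement of a labelled ligand from Neuronal acetylcholine receptor; alpha4/beta2 (Rattus norvegicus); a lower number here means a stronger inhibitor, a higher number a weaker inhibitor:
compound 1 `CN1CCC[C@H]1COc1cccnc1Br` gives 451 nM
compound 2 `CN1CCC[C@H]1COc1cccnc1[N+](=O)[O-]` gives 9000 nM
compound 3 `Cc1cncc(OC[C@@H]2CCCN2C)c1` gives 0.48 nM

Compound 3 stands lowest of the three numbers; compound 1 sits well above it, and compound 2 is the highest of all. For the measured compounds named here, the single measured step, a 20-fold higher number from compound 1 to compound 2 (1.30 log units; beyond the scatter), shows that exchanging one small substituent on the shared core for another can move the number a long way. Compound 4 `CC(=O)c1cncc(OC[C@@H]2CCCN2C)c1` differs from compound 3 by acetyl in place of methyl on an aromatic carbon. Going by the values given here, no measured step covers this exchange: the step from compound 1 to compound 2 concerns other groups at another carbon, so it bears on compound 4 only as a sign that substituent swaps on this core are not free. Compound 3 is so strong in this assay that an increase seems the likelier direction, and a moderate step of a 6.3-fold higher number from compound 3 to compound 4 (0.80 log units; beyond the scatter) is expected. For compound 4 the estimate in this assay is 3 nM, with a range from 0.5 nM to 30 nM.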

Compound 4, inhibition constant: 1.19 nM
The estimate for compound 4 lay 2.5-fold (0.40 log units) above the measured number, and the stated range covers the measured number.
By their numbers in this assay, from the lowest: compound 3; then compound 4; then compound 1; then compound 2.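

In this assay, acetyl in place of methyl on this aromatic carbon, two atoms from the ring nitrogen, costs only a modest step (a 2.5-fold higher number from compound 3 to compound 4 (0.39 log units; beyond the scatter)) even though the entering group brings more heavy atoms and a hydrogen-bond acceptor. For the compounds shown here, the one earlier step (a 20-fold higher number from compound 1 to compound 2 (1.30 log units; beyond the scatter)) was large, but it concerned bromo and nitro at another carbon, so this is the first sign that a substituent swap on the shared core can move the number only a little. No measurement is available to explain why this exchange changes the number so little.

Going by these compounds, it remains open whether an amine, a carboxylic acid or a longer chain such as propionyl would stay as close to compound 3 at this carbon. On these data alone, it is also open whether acetyl would give a similar step at the carbon that carries bromo in compound 1.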